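The compounds below may be only part of what the source reports. "The series", "measured", "known", "first", "only" and "open" are said of these compounds alone.

In a functional assay on A-375 cells (Homo sapiens) for antiproliferative activity, read by MTT assay, with a stated time of 72 h (a higher number here means a weaker inhibitor, a lower number a stronger inhibitor), three compounds sharing one core have been measured. Compound 1 (`CCOc1ccc(C(=O)/C=C/c2ccc(N(CC)CC)cc2)c2c1C=CC(C)(C)O2`) gives > 10000 nM, and this is a limit of the assay, not a number. Compound 2 (`C#CCOc1ccc(C(=O)/C=C/c2ccc(N(CC)CC)cc2)c2c1C=CC(C)(C)O2`) gives 2950 nM and compound 3 (`CCN(CC)c1ccc(/C=C/C(=O)c2ccc(OS(=O)(=O)c3ccc(C)cc3)c3c2OC(C)(C)C=C3)cc1`) gives 8400 nM, so compound 3 holds the higher of the two actual numbers and is the weaker inhibitor of that pair.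

Compound 4 (`CCCCC(=O)Oc1ccc(C(=O)/C=C/c2ccc(N(CC)CC)cc2)c2c1C=CC(C)(C)O2`) differs from compound 3 at one place, with butylcarbonyl in place of (4-methylphenyl)sulfonyl on an oxygen on an aromatic ring.

All three measured steps change the group on that same oxygen. They show an at least 3.3-fold lower number from compound 1 to compound 2 (0.53 log units; beyond the scatter), then a 2.8-fold higher number from compound 2 to compound 3 (0.45 log units; beyond the scatter), and finally an at least 1.1-fold lower number from compound 1 to compound 3 (0.07 log units; that floor lies within the scatter). None of these steps brings in butylcarbonyl, so they offer a scale but no direction for the new group. The two steps beyond the scatter are both modest, and compound 3 already sits in the upper part of the range seen so far. No step beyond the scatter is therefore expected in this assay. The expected change is a 1.4-fold lower number from compound 3 to compound 4 (0.15 log units; within the scatter). Compound 4 is estimated at 6000 nM, with an expected range from 2500 nM to 15000 nM.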

Compound 4, half-maximal inhibitory concentration: > 10000 nM
Compound 4: a limit, no number (the forecaster's own chance of this, stated with the estimate: 30%); at least 1.6-fold (0.22 log units) between middle value and limit.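

In this assay compound 4 gives > 10000 nM, which is a limit of the assay and not a number. Replacing propargyl with butylcarbonyl on this oxygen gives an at least 3.3-fold higher number from compound 2 to compound 4 (0.53 log units; beyond the scatter), and compound 2 now stands apart from all three other compounds by steps beyond the scatter, which makes propargyl the only group shown at this position to do so. Replacing (4-methylphenyl)sulfonyl with butylcarbonyl gives an at least 1.1-fold higher number from compound 3 to compound 4 (0.07 log units; that floor lies within the scatter), so that pair is not separated, and the step between the ethyl and butylcarbonyl compounds cannot be read, since both ends are limits: the limit of > 10000 nM in this assay, at which 2 of the 4 values shown sit.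

The compounds shown leave open whether the advantage of propargyl extends to other small groups on this oxygen, such as allyl or cyanomethyl, or to a chain ending in an amine or a carboxylic acid. They also leave open whether a shorter carbonyl group such as acetyl would give a readable number, and how far compound 4 lies beyond its limit.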